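Swapping a thiazoline for an oxazoline on the sulfonyl-bound carbon

The source may report more compounds than this note shows. Statements on the series, on what has been measured and on what is new or still open speak of the compounds shown alone.

The study measures nitrite release in a functional assay, read by Griess assay, with a stated time of 150 min, tested at 75 ug/mL; a higher number here means a stronger effect of the compound at the concentration tested, a lower number a weaker effect. Going by the values given here, compound 1, `O=S(=O)(CC1=NCCS1)c1c(-c2ccccc2)noc1-c1ccccc1`, is reported in this assay as "not active" (no number reported), so no single number stands for it; it is the only compound here without a numerical read-out. Compound 2, `COc1ccc(-c2noc(-c3ccc(C)cc3)c2S(=O)(=O)CC2=NCCO2)cc1`, gives in this assay 73%. Compound 2 and compound 1 differ in more than one place, so their two values show only that one bears a result and the other does not. Compound 3, `O=S(=O)(CC1=NCCO1)c1c(-c2ccccc2)noc1-c1ccccc1`, has not yet been measured. It differs from compound 1 as follows: a group of 5 heavy atoms (3 carbon, 1 nitrogen, 1 oxygen; one five-membered non-aromatic ring with 2 hetero atoms) in place of a group of 5 heavy atoms (3 carbon, 1 nitrogen, 1 sulfur; one five-membered non-aromatic ring with 2 hetero atoms), on a saturated chain carbon bound to a sulfonyl sulfur. Among the compounds with values here, no measured pair isolates this change. The same entering group is present in compound 2, which gave 73%, but compound 2 carries further substituents on both aryl rings, so the effect of the swap alone is uncertain. An upward step from the inactive compound 1 is expected, of moderate size, beyond the scatter but well short of compound 2. Compound 3 is therefore estimated at 35%, with a range from 5% to 65%.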

Compound 3, a percentage reported as activity, at one concentration (the size of the read-out at that concentration, not a potency): 57.3%
For compound 3 the middle estimate is 22.3 percentage points below the measured one; the range from low to high includes it.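

In this assay, going by these compounds alone, compound 1 stands as "not active" (no number reported) and compound 3 at 57.3% so no step from compound 1 to compound 3 can be read. The compounds shown leave open how large the effect of this exchange of ring groups is on its own. Nothing given here accounts for the result.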